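Growing the amine substituent: from compound 3 to compound 4

The compounds below may be only part of what the source reports. "The series", "measured", "known", "first", "only" and "open" are said of these compounds alone.

Measured so far in an assay on CHO cells for displacement of a labelled ligand from adenosine receptor A3 (Homo sapiens); a lower number here means a stronger inhibitor, a higher number a weaker inhibitor:
compound 1 `CCOC(=O)c1cnc(N(C)C)n2nc(-c3ccco3)nc12` gives 275 nM
compound 2 `CCOC(=O)c1cnc(NC2CCCCC2)n2nc(-c3ccco3)nc12` gives 131 nM
compound 3 `CNc1ncc(C(=O)O)c2nc(-c3ccco3)nn12` gives 15900 nM

Compound 3 stands at the highest of the three numbers in this assay, far above both compound 1 and compound 2, with gaps well beyond the scatter. Compound 4 `COc1ccc(CNc2ncc(C(=O)O)c3nc(-c4ccco4)nn23)cc1` has not yet been measured. It differs from compound 3 in one place: 4-methoxyphenyl in place of hydrogen on a saturated chain carbon bound to a nitrogen on an aromatic ring. Among the measured compounds shown here, the only measured step that resembles this change is a 2.1-fold lower number from compound 1 to compound 2 (0.32 log units; beyond the scatter), where the larger group was likewise placed on the amine nitrogen. That step, though, was seen on the ethyl-ester pair rather than on the core of compound 3, and the group that enters in compound 4 is of a different kind from the cyclohexyl ring, so the guidance is thin. A modest lowering of the number is expected for compound 4, in the direction seen from compound 1 to compound 2, while leaving room for no change beyond the scatter or a move the other way. The expected step for compound 4 is a 3.2-fold lower number from compound 3 to compound 4 (0.50 log units; beyond the scatter). The estimate for compound 4 is 5000 nM, with a range from 1500 nM to 16000 nM.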

Compound 4, inhibition constant: 5520 nM
Estimate against measurement, compound 4: 1.1-fold (0.04 log units) below; the measured number falls inside the stated range.
By their numbers in this assay, from the lowest: compound 2; then compound 1; then compound 4; then compound 3.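

In this assay the change from methyl to 4-methoxybenzyl gives a 2.9-fold lower number from compound 3 to compound 4 (0.46 log units; beyond the scatter) and so shows that, on the core with the free carboxylic acid, this position takes a group with 8 more heavy atoms and an aromatic ring without the number rising. Among the compounds shown here, until now, the only step with a larger group on this amine was a 2.1-fold lower number from compound 1 to compound 2 (0.32 log units; beyond the scatter) in the ethyl ester pair, where cyclohexylamino replaced dimethylamino, so the same direction now appears with a different group and on an acid rather than an ester, and neither step goes against it, though two steps make only a small pattern. No measurement shown here explains why the number falls in either step.

The compounds shown leave open whether the methoxy group plays any part, which a plain benzyl group on the same amine would test against compound 4. They also leave open whether 4-methoxybenzyl would lower the number in the same way with an ethyl ester in place of the carboxylic acid, and how a longer chain between the nitrogen and the aromatic ring would compare.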